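This account rests on a few compounds, and the source may have more. Where it says the series, first, only, none or still open, it means among the compounds named here.

Measured so far in a functional assay on HepG2 cells (Homo sapiens) for antiproliferative activity, read by MTT assay, with a stated time of 96 h; a lower number here means a stronger inhibitor of growth, a higher number a weaker inhibitor of growth:
- Compound 1 `O=C(NO)c1ccc(CNC(=O)c2cc(-c3ccc(F)cc3)[nH]n2)cc1`: 38100 nM
- Compound 2 `O=C(CCCNC(=O)c1cc(-c2ccc(F)cc2)[nH]n1)NO`: 88000 nM

Compound 2 has the higher of the two numbers, so it is the weaker inhibitor of growth here. The gap to compound 1 lies beyond the scatter.

Compound 3 `O=C(CCCCNC(=O)c1cc(-c2ccc(F)cc2)[nH]n1)NO` has not yet been measured in this assay. It differs from compound 2 by one change: (hydroxycarbamoyl)methyl in place of hydroxycarbamoyl on a saturated chain carbon, three bonds along the chain from an amide-type nitrogen. In words, (hydroxycarbamoyl)methyl stands in place of hydroxycarbamoyl on a saturated chain carbon, three bonds along the chain from an amide-type nitrogen. Cut one bond further out, the same difference reads 2-(hydroxycarbamoyl)ethyl to 3-(hydroxycarbamoyl)propyl.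

Going by the values given here, no measured pair shows the effect of this change, so the expectation is a judgement with wide margins. With compound 2 at 88000 nM, a modest shift towards a lower number is expected, although a result within the scatter would not be surprising. The expected step of a 1.8-fold lower number from compound 2 to compound 3 (0.25 log units; within the scatter) is therefore small. Compound 3 is estimated at 50000 nM, with an expected range of 18000 nM to 110000 nM.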

Compound 3, concentration for 50% growth inhibition: > 100000 nM
Compound 3: only a limit was reported (the forecaster's own chance of this, stated with the estimate: 10%); middle value at least 2.0-fold (0.30 log units) from the limit.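

In this assay compound 3 gives > 100000 nM, which is a limit of the assay and not a number. Going by these compounds alone, replacing hydroxycarbamoyl with (hydroxycarbamoyl)methyl on a saturated chain carbon, three bonds along the chain from an amide-type nitrogen, gives an at least 1.1-fold higher number from compound 2 to compound 3 (0.05 log units; that floor lies within the scatter), the first readable step at this position, and it shows no gain in growth inhibition from moving from 2-(hydroxycarbamoyl)ethyl to 3-(hydroxycarbamoyl)propyl. The size of that step remains a floor and cannot be read as a measured difference because the result for compound 3 is bounded only by an assay limit: the limit of > 100000 nM in this assay, at which 1 of the 3 values shown sits.

Still open, as far as these compounds go, is whether a longer chain ending in hydroxycarbamoyl would stay at this limit or return a measurable value, so a single step gives no trend in chain length. Also open, from the compounds shown here alone, is whether a carboxylic acid or an amine in place of the hydroxycarbamoyl group at the end of this chain would give a readable value in this assay.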